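This account rests on a few compounds, and the source may have more. Where it says the series, first, only, none or still open, it means among the compounds named here.

Series notes. Compound 1 `CS(=O)(=O)c1ccc2c(c1)CCN2c1ncnc2c(C3CCN(c4ncccn4)CC3)coc12` carries the shared core with a piperidine bearing a pyrimidin-2-yl group. Among the compounds with values here, in a functional assay on cells for agonist activity at Glucose-dependent insulinotropic receptor (Homo sapiens), read by a luciferase reporter, with a stated time of 4 h (a higher number here means that more compound is needed for the effect, a lower number that less compound is needed), compound 1 gives 512 nM, the only number reported in the set. Within the data shown here, compound 2 `CC(C)(C)OC(=O)N1CCC(c2coc3c(N4CC(C)(C)c5cc(S(C)(=O)=O)ccc54)ncnc23)CC1` replaces that pyrimidinyl with a tert-butyl carbamate on the piperidine nitrogen and alters the core; in this assay compound 2 is reported as "not active" (no number reported), with no number attached, so no step can be drawn from it.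

Compound 3 `CS(=O)(=O)c1ccc2c(c1)CCN2c1ncnc2c(C3CCN(c4ncc(Cl)cn4)CC3)coc12` differs from compound 1 in one place: chloro in place of hydrogen on an aromatic carbon, read one bond further out as pyrimidin-2-yl to 5-chloropyrimidin-2-yl. Among the measured compounds shown here, no measured pair in the set shows a change of this kind, so the direction is not anchored by data. The expected step of a 1.7-fold lower number from compound 1 to compound 3 (0.23 log units; within the scatter) is a modest one toward less compound being needed, though it may not exceed the usual scatter. Compound 3 is estimated at 300 nM, with a range from 100 nM to 900 nM.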

Compound 3, half-maximal effective concentration: 42 nM
For compound 3 the middle estimate is 7.1-fold (0.85 log units) above the measured one, outside the stated range (below it).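

The aromatic carbon two atoms from the ring nitrogen of the pyrimidin-2-yl group responds strongly to substitution: in this assay a single chlorine there gives a 12-fold lower number from compound 1 to compound 3 (1.09 log units; beyond the scatter) and so moves the number well beyond the scatter. Compound 1 alone could not show that this position matters, and compound 2, without a number, offered no comparison. Nothing measured here accounts for the size of the step.

On these data alone, whether fluoro, methyl, methoxy, a nitrile or an amine on the same carbon would give a step of similar size or direction remains open. Also open, as far as these compounds go, is whether the gain from chloro carries over to the altered core of compound 2, since this single pair speaks only for the core of compound 1.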